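This account rests on a few compounds, and the source may have more. Where it says the series, first, only, none or still open, it means among the compounds named here.

Compound 1 `C=CCOc1ccc(-c2cn3c(=O)n(-c4ccccc4)nc3c(N)n2)cc1`: "not determined" (no result reported). Compound 2 `COc1ccc(-c2cn3c(=O)n(-c4ccccc4)nc3c(=O)[nH]2)cc1`: > 30000 nM. Compound 3 `O=c1[nH]c(-c2ccccc2)cn2c(=O)n(-c3ccccc3)nc12`: > 30000 nM.

In a functional assay on cells for antagonist activity at adenosine receptor A2b (Homo sapiens), read by cAMP accumulation, with a stated time of 10 min (a higher number here means a weaker inhibitor, a lower number a stronger inhibitor), compound 1 gives "not determined" (no result reported), so it has no place on the numbers shown. In this assay compound 2 gives only a limit, > 30000 nM. Likewise compound 3 gives only a limit, > 30000 nM. The step that the two limits leave unreadable from compound 2 to compound 3 is therefore unreadable (the limit of > 30000 nM in this assay, at which 2 of the 3 values shown sit). Compound 4 `CCCOc1ccc(-c2cn3c(=O)n(-c4ccccc4)nc3c(N)n2)cc1` differs from compound 1 by ethyl in place of vinyl on a saturated chain carbon bound to an oxygen on an aromatic ring. Among the measured compounds shown here, no measured step bears on this change, and compound 1 itself has no number, so the expectation for compound 4 rests on the shared core alone and is wide. Compound 4 is estimated at 80 nM, with a range from 5 nM to 1500 nM.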

Compound 4, half-maximal inhibitory concentration: > 30000 nM
Compound 4: a limit, no number; the forecaster's own chance of this, stated with the estimate: 20%; middle value at least 370-fold (2.57 log units) away from the limit.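

Compound 4 gives only a limit, > 30000 nM, in this assay. Compound 1 has no number, so no new step can be read between compound 1 and compound 4. What the change from allyloxy to propoxy does to potency stays open, and the values shown offer little to compare: the limit of > 30000 nM in this assay, at which 3 of the 4 values shown sit.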